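Triazole thioether series: benzyl replacing 2-chlorophenyl

The source may hold more compounds than are shown below. What is called first, only, known or untested is meant among the compounds shown, and "the series" means these compounds.

Compound 1: `Cc1cccc(-c2nnc(SCCCN3CCN(c4ccccn4)CC3)[nH]2)c1` — 29400 nM in a functional assay on HL-60 cells (Homo sapiens) for cytotoxicity, read by MTT assay, with a stated time of 24 h; a lower number here means a stronger inhibitor, a higher number a weaker inhibitor
Compound 2: `Clc1ccccc1-c1nnc(SCCCN2CCN(c3ccccn3)CC2)[nH]1` — > 300000 nM in this assay

Compound 2 stands at the weak end of the two compounds measured, and its reading of > 300000 nM is a limit of the assay rather than a number. This is the limit of > 300000 nM in this assay, at which 1 of the 2 values shown sits. Compound 3, `c1ccc(Cc2nnc(SCCCN3CCN(c4ccccn4)CC3)[nH]2)cc1`, differs from compound 2 by benzyl in place of 2-chlorophenyl on an aromatic carbon. For the measured compounds named here, no measured step involves a benzyl group; the only step on this aromatic carbon is an at least 10-fold higher number from compound 1 to compound 2 (1.00 log units; beyond the scatter), which shows that the group here matters but does not point in a direction for benzyl. Compound 3 is therefore expected near the weak end, with an estimated 150000 nM (range 30000 nM to 400000 nM), meaning an expected step of an at least 2.0-fold lower number from compound 2 to compound 3 (0.30 log units; that floor lies within the scatter).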

Compound 3, half-maximal inhibitory concentration: > 300000 nM
Compound 3: no number, only a limit (the forecaster's own chance of this, stated with the estimate: 40%); middle value at least 2.0-fold (0.30 log units) from the limit.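

Benzyl in place of 3-methylphenyl gives an at least 10-fold higher number from compound 1 to compound 3 (1.00 log units; beyond the scatter), so a second group on this aromatic carbon, not 2-chlorophenyl alone, loses the reading of compound 1 in this assay. The step between compound 2 and compound 3 cannot be read, so benzyl and 2-chlorophenyl cannot be ranked. Compound 3 joins compound 2 at the limit of the assay: the limit of > 300000 nM in this assay, at which 2 of the 3 values shown sit.

As far as these compounds go, whether unsubstituted phenyl would keep the reading of compound 1 remains open. So does whether an amine or a carboxylic acid on this aromatic carbon would give a measurable number.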